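The source may hold more compounds than are shown below. What is called first, only, known or untested is meant among the compounds shown, and "the series" means these compounds.

The measured compounds:

Compound 1, `Cc1cccc(NC(=O)C2(C(=O)Nc3ccc(Nc4ncc5cc(C(=O)N(C)C)n(C6CCCC6)c5n4)cc3)CC2)c1`, in a functional assay on A549 cells (Homo sapiens) for inhibition, read by CCK-8 assay, with a stated time of 72 h, tested at 1 uM (on this read-out higher numbers stand for more inhibition of growth at the one concentration tested and lower numbers for less inhibition of growth), gives 35.2%.
Compound 2, `CN(C)C(=O)c1cc2cnc(Nc3ccc(NC(=O)C4(C(=O)Nc5ccc(Cl)cc5)CC4)cc3)nc2n1C1CCCC1`, gives 24.7%.
Compound 3, `Cc1ccc(NC(=O)C2(C(=O)Nc3ccc(Nc4ncc5cc(C(=O)N(C)C)n(C6CCCC6)c5n4)cc3)CC2)cc1`, gives 40.2%.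

Among these three numbers compound 2 stands lowest: the nearest, compound 1, lies a number 10.5 percentage points lower from compound 1 to compound 2 (beyond the scatter) away, and the furthest, compound 3, lies a number 15.5 percentage points higher from compound 2 to compound 3 (beyond the scatter) away. The two methylphenyl compounds themselves sit close together, a number 5 percentage points higher from compound 1 to compound 3 (within the scatter), so the spread within this small set is carried by the chloro compound alone.

The next compound, compound 4, `COC(=O)c1cccc(NC(=O)C2(C(=O)Nc3ccc(Nc4ncc5cc(C(=O)N(C)C)n(C6CCCC6)c5n4)cc3)CC2)c1`, differs from compound 2 in one place: 3-(methoxycarbonyl)phenyl in place of 4-chlorophenyl on an amide-type nitrogen.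

For the measured compounds named here, no measured step touches a methoxycarbonyl group, so no direct precedent exists for this change. What bears on it is the pair of steps away from compound 2: going to a methylphenyl on that amide-type nitrogen gave a number 10.5 percentage points lower from compound 1 to compound 2 (beyond the scatter) in reverse and a number 15.5 percentage points higher from compound 2 to compound 3 (beyond the scatter), both beyond the scatter. Replacing the chlorine-bearing ring with any other aryl seen here has returned the number to the level of compounds 1 and 3, so a modest rise is the expectation for compound 4, roughly a number 8.3 percentage points higher from compound 2 to compound 4 (within the scatter). The estimate for compound 4 in this assay is 33%, with a range from 20% to 47%.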

Compound 4, percent growth inhibition at one concentration: 10.5%
Compound 4: the middle estimate sits 22.5 percentage points above what was measured, and the stated range ends above it.
By their numbers in this assay, from the lowest: compound 4; then compound 2; then compounds 1 and 3 (each within the scatter of the next).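

In this assay, the aryl group on this amide-type nitrogen can take the number below the level of the 4-chlorophenyl compound, which had been the lowest in the set, with a number 14.2 percentage points lower from compound 2 to compound 4 (beyond the scatter). The chloro compound is therefore no longer the only one to depart from the two methylphenyl compounds, and the gaps to those two are wider still, with a number 29.7 percentage points lower from compound 3 to compound 4 (beyond the scatter) and a number 24.7 percentage points lower from compound 1 to compound 4 (beyond the scatter), the latter for methoxycarbonyl in place of methyl on an aromatic carbon. Nothing available here accounts for these falls.

The compounds shown leave open whether the fall belongs to the methyl ester as such or would also follow a carboxylic acid, a primary amide or an acetyl group on the same phenyl ring. They also leave open how far this order of compounds holds at other concentrations, since each number comes from a single tested concentration and says nothing of the full concentration response.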